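The source may hold more compounds than are shown below. What is called first, only, known or untested is meant among the compounds shown, and "the series" means these compounds.

Compound 1 `CN(C)c1cc2[nH]c(C3CCCCC3)nc2cc1NC(=O)c1ccc(Br)cc1` is the starting point here. In an ADME assay on Vero cells (Chlorocebus sabaeus) for cytotoxicity, read by resazurin assay, with a stated time of 3 days (a higher number here means a weaker inhibitor, a lower number a stronger inhibitor), compound 1 gives only a limit of the assay, > 100 ug/mL. Compound 2 `O=C(Nc1cc2nc(C3CCCCC3)[nH]c2cc1N1CCCC1)c1ccc(Br)cc1` likewise gives only a limit in this assay, > 100 ug/mL. The step that the two limits leave unreadable from compound 1 to compound 2 is therefore not readable, and the two values sit at the limit of > 100 ug/mL in this assay, at which 2 of the 2 values shown sit. Compound 3 `CCCc1ccc(C(=O)Nc2cc3nc(C4CCCCC4)[nH]c3cc2N(C)C)cc1` differs from compound 1 by propyl in place of bromo on an aromatic carbon. Within the data shown here, no measured step bears on this change, since both known values are limits. Compound 3 is expected to stay at the limit as well, estimated at 100 ug/mL with a range from 50 ug/mL to 200 ug/mL, a step of a number no higher from compound 1 to compound 3 (the limit leaves the size open) that is expected to show no readable change.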

Compound 3, half-maximal inhibitory concentration: > 100 ug/mL
Compound 3 ended at the assay's limit (the forecaster's own chance of this, stated with the estimate: 75%); the middle value lies on the limit itself.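

No step can be read between compound 1 and compound 3, as both stand only at a limit in this assay: the limit of > 100 ug/mL in this assay, at which 3 of the 3 values shown sit.

The compounds shown leave open how large either change, pyrrolidin-1-yl for dimethylamino or propyl for bromo, is in this assay.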